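Deacetylation steps in a polyacetylated macrolide series

This account rests on a few compounds, and the source may have more. Where it says the series, first, only, none or still open, it means among the compounds named here.

Measured so far:
compound 1, `C=C/C=C\[C@H](C)[C@H](OC(N)=O)[C@@H](C)[C@H](OC(C)=O)[C@@H](C)C/C(C)=C\[C@H](C)[C@@H](OC(C)=O)[C@@H](C)/C=C\[C@H](C[C@@H]1OC(=O)[C@H](C)[C@@H](OC(C)=O)[C@H]1C)OC(C)=O`, 837 nM
compound 2, `C=C/C=C\[C@H](C)[C@H](OC(N)=O)[C@@H](C)[C@H](O)[C@@H](C)C/C(C)=C\[C@H](C)[C@@H](OC(C)=O)[C@@H](C)/C=C\[C@H](C[C@@H]1OC(=O)[C@H](C)[C@@H](OC(C)=O)[C@H]1C)OC(C)=O`, 166 nM
compound 3, `C=C/C=C\[C@H](C)[C@H](OC(N)=O)[C@@H](C)[C@H](OC(C)=O)[C@@H](C)C/C(C)=C\[C@H](C)[C@@H](O)[C@@H](C)/C=C\[C@@H](O)C[C@@H]1OC(=O)[C@H](C)[C@@H](OC(C)=O)[C@H]1C`, 1150 nM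

Compound 4, `C=C/C=C\[C@H](C)[C@H](OC(N)=O)[C@@H](C)[C@H](O)[C@@H](C)C/C(C)=C\[C@H](C)[C@@H](O)[C@@H](C)/C=C\[C@@H](O)C[C@@H]1OC(=O)[C@H](C)[C@@H](OC(C)=O)[C@H]1C`, is not yet measured in a functional assay on P388 cells (Mus musculus) for cytotoxicity, read by MTT assay, with a stated time of 48 h; on this read-out lower numbers stand for stronger inhibition and higher numbers for weaker inhibition.

Compound 2 arises from compound 1 by hydrogen in place of acetyl on an oxygen on a saturated carbon, and the step is a 5.0-fold lower number from compound 1 to compound 2 (0.70 log units; beyond the scatter). Compound 4 arises from compound 3 by the same change, (hydrogen in place of acetyl on an oxygen on a saturated carbon), at a place described in the same words. The difference between the core of compound 1 and the core of compound 3 is not broken down here; in this assay compound 3 gives 1150 nM against compound 1 at 837 nM, which lies within the scatter.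

For compound 4 a step of a 3.8-fold lower number from compound 3 to compound 4 (0.58 log units; beyond the scatter) is expected, resting on the step of a 5.0-fold lower number from compound 1 to compound 2 (0.70 log units; beyond the scatter). The difference between the cores of compound 1 and compound 3 is not counted, and the expected step is softened on that account. Compound 4 is therefore estimated at 300 nM, between 100 nM and 1000 nM.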

Compound 4, half-maximal inhibitory concentration: 12.6 nM
Beside the measured number, compound 4's estimate is 24-fold (1.38 log units) above it; the whole stated range lies above it.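

In this assay the change from acetoxy to hydroxy gives a 91-fold lower number from compound 3 to compound 4 (1.96 log units; beyond the scatter) and so lowers the number on both cores, but its size does not carry over: the same change on two cores in this assay, a 5.0-fold lower number (0.70 log units; beyond the scatter) from compound 1 to compound 2 and a 91-fold lower number (1.96 log units; beyond the scatter) from compound 3 to compound 4, 18-fold (1.26 log units) apart, beyond the scatter of two such steps. For these two pairs the direction of the change holds, while the step measured on one core does not give the size of the step on the other. The two pairs do not show which part of the cores sets this gap, nor how the change behaves on any further core.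

The compounds shown leave open whether the gain comes from the free hydroxy or from the loss of acetyl. A methyl ether, a longer chain ester or an amine at the same place would separate the two.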